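Swapping a sulfonyl for a urea on compound 3

The source may report more compounds than this note shows. Statements on the series, on what has been measured and on what is new or still open speak of the compounds shown alone.

Of the compounds shown here, three have been measured in a functional assay on MDA-MB-231 cells (Homo sapiens) for antiproliferative activity, read by MTT assay, with a stated time of 48 h (a higher number here means a weaker inhibitor, a lower number a stronger inhibitor), with these results.

compound 1 `C=CS(=O)(=O)N1CCN(c2ncnc3sc(-c4ccc(F)nc4)cc23)CC1` gives 16000 nM
compound 2 `C=CS(=O)(=O)N1CCN(c2ncnc3sc(-c4cnn(Cc5ccccc5)c4)cc23)CC1` gives 19100 nM
compound 3 `CCS(=O)(=O)N1CCN(c2ncnc3sc(-c4ccc(N5CCN(C)CC5)cc4)cc23)CC1` gives 7330 nM

Compound 3 has the lowest number of the three, so it is the strongest inhibitor of the set in this assay. Its gaps to compound 1 and to compound 2 both lie beyond the scatter. Even so, the whole set spans a narrow band of weak activity, with compound 3 at 7330 nM and compound 2 at 19100 nM.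

The next compound is compound 4 `CCCNC(=O)N1CCN(c2ncnc3sc(-c4ccc(N5CCN(C)CC5)cc4)cc23)CC1`, which keeps the rest of compound 3 unchanged. It carries propylcarbamoyl in place of ethylsulfonyl on an amine nitrogen in a ring.

Among the measured compounds shown here, no measured pair differs in one place only, so the data give no direct guide to this exchange. The expectation therefore rests on that narrow band, and no step beyond the scatter is expected in either direction. The estimated change is a 1.1-fold higher number from compound 3 to compound 4 (0.04 log units; within the scatter). The expected value for compound 4 is 8000 nM, with an estimated range from 3000 nM to 20000 nM.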

Compound 4, half-maximal inhibitory concentration: 8330 nM
For compound 4 the middle estimate is 1.0-fold (0.02 log units) below the measured one; low and high end bracket the measured number.
By their numbers in this assay, from the lowest: compounds 3, 4, 1 and 2 (each within the scatter of the next, the first and the last beyond it).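

In this assay, among the compounds shown here, exchanging ethylsulfonyl for propylcarbamoyl on an amine nitrogen in a ring gives a 1.1-fold higher number from compound 3 to compound 4 (0.06 log units; within the scatter), the first comparison in this set that isolates a single change, and it does not separate the two groups. The entering group carries a hydrogen-bond donor that ethylsulfonyl lacks, and it has a nitrogen and no sulfur, yet this difference in make-up comes with no step beyond the scatter at this position on the shared core. Nothing available here explains why the two groups read alike, and no measurement of any property of either compound bears on the result.

The compounds shown leave open whether this flat response extends to other groups on the same nitrogen, such as a longer chain on the urea, a phenyl urea, a simple acetyl amide or a carboxylic acid-bearing chain. They also leave open whether the exchange would read the same alongside the other aromatic groups on the shared core, since compound 1 and compound 2 differ from this pair in more than one place.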